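Aryl Swap on the Pyrazole Nitrogen of a Urea Antagonist

The source may hold more compounds than are shown below. What is called first, only, known or untested is meant among the compounds shown, and "the series" means these compounds.

Compound 1 `Cn1ncc2c(NC(=O)NCc3cc(C(F)(F)F)nn3-c3cccc(Cl)c3)cccc21`: 2.3 nM
Compound 2 `Cn1ncc2c(NC(=O)NCc3cc(C(C)(C)C)nn3-c3cccc(Cl)c3)cccc21`: 0.4 nM

In an assay on CHO-K1 cells for antagonist activity at transient receptor potential cation channel subfamily V member 1 (Homo sapiens), read by FLIPR and calcium flux, with a stated time of 6 min (a lower number here means a stronger inhibitor, a higher number a weaker inhibitor), compound 2 stands lowest of the two numbers, with compound 1 nearest at a 5.8-fold lower number from compound 1 to compound 2 (0.76 log units; beyond the scatter). Compound 3 `Cn1ncc2c(NC(=O)NCc3cc(C(C)(C)C)nn3-c3ccc(F)cc3)cccc21` differs from compound 2 by 4-fluorophenyl in place of 3-chlorophenyl on an aromatic nitrogen. Going by the values given here, no measured step touches this part of the molecule; the single step, from trifluoromethyl to tert-butyl, concerns another group and gives no guide here. The expectation is therefore loose: a shift of a 3.8-fold higher number from compound 2 to compound 3 (0.57 log units; beyond the scatter), weakening rather than strengthening. Compound 3 is expected at 1.5 nM, within 0.4 nM to 6 nM.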

Compound 3, inhibition constant: 4.5 nM
Compound 3: middle estimate off by 3.0-fold (0.48 log units), on the low side; the range from low to high includes it.
By their numbers in this assay, from the lowest: compound 2; then compounds 1 and 3 (each within the scatter of the next).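

In this assay the aryl group on the aromatic nitrogen proves sensitive, with an 11-fold higher number from compound 2 to compound 3 (1.05 log units; beyond the scatter) when 4-fluorophenyl replaces 3-chlorophenyl, a large step with the tert-butyl group held constant. This one change alters both the halogen and its place on the phenyl ring, so the step belongs to the swap as a whole. Nothing available explains the size of the step. Going by these compounds, it remains open whether the halogen or its place matters more, and how a plain phenyl, a methoxyphenyl or a pyridine ring would read here.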